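A Methyl Added to the Phenyl of Compound 2

The source may hold more compounds than are shown below. What is called first, only, known or untested is meant among the compounds shown, and "the series" means these compounds.

Compound 1, `O=c1[nH]cc(S(=O)(=O)Nc2ccccc2-c2cn(-c3cccc(Cl)c3)nn2)c(=O)[nH]1`: in a functional assay on SGC-7901 cells (Homo sapiens) for antiproliferative activity, read by MTT assay, with a stated time of 24 h (a lower number here means a stronger inhibitor, a higher number a weaker inhibitor), compound 1 gives 2270 nM.
Compound 2, `O=c1[nH]cc(S(=O)(=O)Nc2cccc(-c3cn(-c4ccccc4)nn3)c2)c(=O)[nH]1`: in this assay compound 2 gives 17200 nM.

Going by the values given here, compound 2 stands at the higher of the two numbers, so it is the weaker of the pair; compound 1, its only neighbour, sits well below it, and that gap lies beyond the scatter. Compound 3, `Cc1ccc(-n2cc(-c3cccc(NS(=O)(=O)c4c[nH]c(=O)[nH]c4=O)c3)nn2)cc1`, differs from compound 2 by methyl in place of hydrogen on an aromatic carbon. Among the compounds with values here, no measured pair of compounds shows this change, so there is no step to lean on. A single methyl on the outer phenyl ring is a small change, and compound 3 is expected to end up close to compound 2, with any step in this assay staying within the scatter. The step of a 1.2-fold lower number from compound 2 to compound 3 (0.09 log units; within the scatter) is therefore estimated to be small. Compound 3 is expected to give 14000 nM, within a range from 5000 nM to 40000 nM.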

Compound 3, half-maximal inhibitory concentration: 9430 nM
The estimate for compound 3 lay 1.5-fold (0.17 log units) above the measured number; the measured number falls inside the stated range.
By their numbers in this assay, from the lowest: compound 1; then compounds 3 and 2 (each within the scatter of the next).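

In this assay, going by these compounds alone, phenyl to 4-methylphenyl gives the first reading of this change, a 1.8-fold lower number from compound 2 to compound 3 (0.26 log units; within the scatter), so a methyl on this aromatic carbon, para to a large group, leaves compound 3 indistinguishable from compound 2. Within the data shown here, the earlier compounds offered no pair that differed in one place, so this is also the first direct look at this position, though it rests on a single pair. No measured property bears on this result, and the data offer no explanation for it.

As far as these compounds go, whether the number stays as flat with an amine, a carboxylic acid or a longer chain such as propyl on this same carbon remains open. From the compounds shown here alone, it is also open whether a methyl added to the outer ring of compound 1 would give a similarly small step.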